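A few compounds are considered here, and "the series" means these few. Any claim that something is new, unique, unknown or untested is made for them only; others in the source may bear on it.

The shared core of compound 1 `COc1ccc(/C=C/C(=O)c2ccc(OC)c3c2OC(C)(C)C=C3)cc1OCCCN(C)C` is kept in all three measured compounds. In a functional assay on HepG2 cells (Homo sapiens) for cytotoxicity, read by MTT assay (on this read-out lower numbers stand for stronger inhibition and higher numbers for weaker inhibition), compound 1 gives 5550 nM, the second highest of the three numbers. Compound 3 `COc1ccc(/C=C/C(=O)c2ccc(OC)c3c2OC(C)(C)C=C3)cc1CS(C)(=O)=O` gives 9180 nM, and the step of a 1.7-fold higher number from compound 1 to compound 3 (0.22 log units; within the scatter) is within the scatter, so these two cannot be told apart. Compound 2 `COc1ccc(/C=C/C(=O)c2ccc(OC)c3c2OC(C)(C)C=C3)cc1OC(=O)c1ccco1` gives 370 nM, and the step of a 15-fold lower number from compound 1 to compound 2 (1.18 log units; beyond the scatter) is the only large movement seen here.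

Compound 4 `COc1ccc(/C=C/C(=O)c2ccc(OC)c3c2OC(C)(C)C=C3)cc1OS(=O)(=O)Cc1ccccc1` differs from compound 1 in one place: benzylsulfonyl in place of 3-(dimethylamino)propyl on an oxygen on an aromatic ring. The step that bears most directly on this change is a 15-fold lower number from compound 1 to compound 2 (1.18 log units; beyond the scatter), where the same 3-(dimethylamino)propyl on the same oxygen was exchanged for a (furan-2-yl)carbonyl and the number fell far beyond the scatter. The step of a 1.7-fold higher number from compound 1 to compound 3 (0.22 log units; within the scatter), which swaps the whole 3-(dimethylamino)propoxy for a (methylsulfonyl)methyl on an aromatic carbon, stayed within the scatter, so it gives little guidance for a change on the oxygen. Because compound 2 shows 370 nM after losing the same group, compound 4 is expected to move to a lower number, though less surely than an identical replacement would. The step of a 4.6-fold lower number from compound 1 to compound 4 (0.67 log units; beyond the scatter) is the expected outcome. Compound 4 is therefore estimated at 1200 nM, with a range from 300 nM to 5000 nM.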

Compound 4, half-maximal inhibitory concentration: > 10000 nM
Compound 4: a limit, no number; the forecaster's own chance of this, stated with the estimate: 5%; at least 8.3-fold (0.92 log units) between middle value and limit.
By their numbers in this assay, from the lowest: compound 2; then compounds 1 and 3 (each within the scatter of the next). At a limit, above all of these: compound 4.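

In this assay compound 4 gives > 10000 nM, which is a limit of the assay and not a number. Benzylsulfonyl in place of (furan-2-yl)carbonyl on an oxygen on an aromatic ring gives an at least 27-fold higher number from compound 2 to compound 4 (1.43 log units; beyond the scatter), so what enters on this oxygen counts, and the loss of 3-(dimethylamino)propyl does not by itself bring a lower number. The steps of an at least 1.8-fold higher number from compound 1 to compound 4 (0.25 log units; that floor lies within the scatter) and an at least 1.0-fold higher number from compound 3 to compound 4 (0.03 log units; that floor lies within the scatter) cannot be read: their floors lie within the scatter, and the limit does not tell how far they reach.

The sulfur-bearing link and the benzyl end of benzylsulfonyl enter together, so the compounds shown leave open which of the two parts goes with the high number in compound 4. A benzoyl group or a methylsulfonyl group on the same oxygen would pull these parts apart, and whether either stays near compound 2 or goes with compound 4 remains an open question.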